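From Trifluoromethyl to Trifluoromethoxy on the Anilide Ring

The source may report more compounds than this note shows. Statements on the series, on what has been measured and on what is new or still open speak of the compounds shown alone.

Compound 2 `O=C(CN1CCC(c2cccc[n+]2[O-])CC1)Nc1cccc(C(F)(F)F)c1` gives 75% in a functional assay on HEK293 cells for agonist activity at D(4) dopamine receptor (Homo sapiens), read by FLIPR (on this read-out lower numbers stand for smaller maximal responses and higher numbers for larger maximal responses), the highest of the three measured numbers. Compound 1 `CSc1cccc(NC(=O)CN2CCC(c3cccc[n+]3[O-])CC2)c1` gives 56% in this assay, and compound 3 `COc1ccccc1C1CCN(CNC(=O)c2cccc(C)c2)CC1` gives 55%, both beyond the scatter below compound 2. Among the measured compounds shown here, the only measured change at this aromatic carbon is a number 19 percentage points higher from compound 1 to compound 2 (beyond the scatter), a modest rise. Compound 4 `O=C(CN1CCC(c2cccc[n+]2[O-])CC1)Nc1cccc(OC(F)(F)F)c1` differs from compound 2 by trifluoromethoxy in place of trifluoromethyl on an aromatic carbon. For the measured compounds named here, no measured pair exchanges trifluoromethyl for trifluoromethoxy, so the direction remains open. Given that the one step at this carbon was modest, the step is expected to stay within the scatter, a number 5 percentage points lower from compound 2 to compound 4 (within the scatter). Compound 4 is therefore estimated at 70%, within 50% to 90% in this assay.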

Compound 4, largest response reached (reported as efficacy), in percent of the reference or control that the assay uses: 51%
Estimate against measurement, compound 4: 19 percentage points above; the range from low to high includes it.
By their numbers in this assay, from the lowest: compounds 4, 3 and 1 (each within the scatter of the next); then compound 2.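

Trifluoromethoxy in place of trifluoromethyl brings a number 24 percentage points lower from compound 2 to compound 4 (beyond the scatter), so in this assay these two fluorinated groups are not interchangeable at this aromatic carbon. Trifluoromethoxy in place of methylsulfanyl brings a number 5 percentage points lower from compound 1 to compound 4 (within the scatter), which leaves trifluoromethyl alone in standing apart among the three groups compared on this core. Nothing measured here explains this difference. On these data alone, whether a nitrile or a chlorine atom at this carbon would match trifluoromethyl or the other two groups remains open. So does whether the same order would hold on a different core.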